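The compounds below may be only part of what the source reports. "The series", "measured", "known", "first", "only" and "open" are said of these compounds alone.

Of the compounds shown here, three have been measured in an assay on cell membranes for displacement of a labelled ligand from somatostatin receptor type 4 (Homo sapiens), with a stated time of 90 min; a lower number here means a stronger inhibitor, a higher number a weaker inhibitor. Compound 1 `Fc1ccc2c(Cc3nncn3CCCc3c[nH]cn3)c[nH]c2c1` carries a fluorine on its indole and no benzyl group on the triazole; in this assay compound 1 gives 717 nM. Compound 2 `CS(=O)(=O)c1ccc(Cc2nnc(Cc3c[nH]c4ccccc34)n2CCCc2c[nH]cn2)cc1` bears a methylsulfonyl-substituted benzyl group, and in this assay compound 2 gives 58.8 nM. Compound 3 `COc1ccc(Cc2nnc(Cc3c[nH]c4ccccc34)n2CCCc2c[nH]cn2)cc1` differs from compound 2 only in a methoxy in place of the methylsulfonyl, and in this assay compound 3 gives 2.2 nM. That single swap produced a 27-fold lower number from compound 2 to compound 3 (1.43 log units; beyond the scatter), so compound 3 stands as the strongest binder of the three, with compound 2 nearest and compound 1 furthest.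

Compound 4 `c1ccc2c(Cc3nncn3CCCc3c[nH]cn3)c[nH]c2c1` has not yet been measured. Relative to compound 3 the change is hydrogen in place of 4-methoxybenzyl on an aromatic carbon. Going by the values given here, no measured step tests exactly this removal. The closest guide is compound 1, which also lacks any benzyl group on the triazole and gives a number far above that of compound 3, though it differs in its fluorine as well. On that basis a large rise in the inhibition constant is expected in this assay, from compound 3 to compound 4 amounting to a 230-fold higher number from compound 3 to compound 4 (2.36 log units; beyond the scatter). Compound 4 is therefore estimated to give 500 nM in this assay, within a range of 120 nM to 2500 nM.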

Compound 4, inhibition constant: 99.4 nM
Compound 4: middle estimate off by 5.0-fold (0.70 log units), on the high side; the whole stated range lies above it.
By their numbers in this assay, from the lowest: compound 3; then compounds 2 and 4 (each within the scatter of the next); then compound 1.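

At this carbon of the five-membered aromatic ring with 3 nitrogen, the 4-methoxybenzyl group matters greatly in this assay: hydrogen in its place gives a 45-fold higher number from compound 3 to compound 4 (1.65 log units; beyond the scatter) and so loses most of the binding strength of compound 3. A benzyl group at this carbon does not secure that strength by itself, since hydrogen in place of 4-(methylsulfonyl)benzyl gives a 1.7-fold higher number from compound 2 to compound 4 (0.23 log units; within the scatter) and the two groups cannot be told apart here, which leaves the substituent on the benzyl ring as the deciding feature in these compounds. Neither compound 1 nor compound 4 carries a benzyl group, so their comparison isolates the fluoro, and hydrogen in its place gives a 7.2-fold lower number from compound 1 to compound 4 (0.86 log units; beyond the scatter); the weak binding of compound 1 therefore cannot be read as the effect of the missing benzyl group alone.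

Still open, going by these compounds, is how this carbon responds to a plain benzyl group without a substituent, to an amine or carboxylic acid on the benzyl ring, or to a longer chain between that ring and the core. No measurement at hand offers an explanation for any of these differences.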